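A few compounds are considered here, and "the series" means these few. Any claim that something is new, unique, unknown or untested is made for them only; others in the source may bear on it.

Measured so far in an assay on HL-60 cells for inhibition of glutathione S-transferase P (Homo sapiens), read by spectrophotometry, tested at 20 uM; a lower number here means less inhibition, a higher number more inhibition at the concentration tested (going by the name of the read-out):
- compound 1, `Cc1cccc2c1N(CC(=O)O)C/C(=C\c1cccc(O)c1)C2=O` — compound 1 gives 75.6%
- compound 2, `COc1cccc(/C=C2\CN(CC(=O)O)c3ccc(C)cc3C2=O)c1` — compound 2 gives 14.4%
- compound 3, `COc1cc(/C=C2\CN(CC(=O)O)c3c(C)cccc3C2=O)cc(OC)c1OC` — compound 3 gives 0.85%

Compound 1 stands highest of the three numbers in this assay; compound 2 lies well below it, beyond the scatter, and compound 3 is the furthest down, also beyond the scatter. Within the data shown here, no pair of measured compounds differs in a single place, so no measured step is available to lean on.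

The next compound is compound 4, `Cc1ccc(/C=C2\CN(CC(=O)O)c3c(C)cccc3C2=O)cc1`. Against compound 1 the difference is 4-methylphenyl in place of 3-hydroxyphenyl on a double-bonded chain carbon bound to a double-bonded ring carbon. The two compounds that carry methoxy in place of hydroxyl on that ring, compound 2 and compound 3, both sit far below compound 1, which suggests that losing the hydroxyl costs inhibition, though neither of them is a clean single-change comparison and compound 2 also differs in its core.

For compound 4 a sizeable downward step is expected, a number 55.6 percentage points lower from compound 1 to compound 4 (beyond the scatter), beyond the scatter. The estimate for compound 4 is 20% with a range from 3% to 50%.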

Compound 4, a percentage reported as inhibition, at one concentration (the size of the read-out at that concentration, not a potency): 46.8%
Estimate against measurement, compound 4: 26.8 percentage points below; measured number inside the range.
By their numbers in this assay, from the lowest: compound 3; then compound 2; then compound 4; then compound 1.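

In this assay the series gains its first single-place comparison, with a number 28.8 percentage points lower from compound 1 to compound 4 (beyond the scatter) for 4-methylphenyl in place of 3-hydroxyphenyl on a double-bonded chain carbon bound to a double-bonded ring carbon. The change lowers inhibition, but compound 4 still gives 46.8%, so on the core of compound 1 an aromatic ring with no hydrogen-bond donor or acceptor keeps a sizeable part of the reading. Nothing measured here bears on the reason for this step.

This single step combines the loss of the hydroxyl, the gain of the methyl and a change in where the substituent sits on the ring, and a 3-methylphenyl or 4-hydroxyphenyl group would be needed to separate these. As far as these compounds go, how an amine or a carboxylic acid would read at this position also remains open.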